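Methylsulfonyl in Place of Bromo on a Tolerated Scaffold

The compounds below may be only part of what the source reports. "The series", "measured", "known", "first", "only" and "open" are said of these compounds alone.

Three compounds sharing one core have been examined in an ADME assay on HEK293 cells (Homo sapiens) for cytotoxicity, read by CellTiter-Glo and resazurin assay, with a stated time of 72 h; on this read-out higher numbers stand for an effect only at larger amounts of compound and lower numbers for an effect already at smaller amounts. Compound 1 `CCOC(=O)CCCCCOc1cccc(CN(C(=O)c2ccc(-c3cccc(N(C)C)c3)cc2)C(C)C)c1` carries a 3-(dimethylamino)phenyl group; in this assay compound 1 gives > 26000 nM, which is a limit of the assay and not a number. Compound 2 `CCOC(=O)CCCCCOc1cccc(CN(C(=O)c2ccc(-c3cc(OC)cc(OC)c3)cc2)C(C)C)c1` bears a 3,5-dimethoxyphenyl group, and in this assay compound 2 gives > 26000 nM, again a limit. Compound 3 `CCOC(=O)CCCCCOc1cccc(CN(C(=O)c2ccc(-c3cccc(Br)c3)cc2)C(C)C)c1` carries a 3-bromophenyl group; in this assay compound 3 gives > 26000 nM, also a limit. Compound 3 therefore stands at the same limit as the other two, and none of the three steps can be sized: a step that the two limits leave unreadable from compound 1 to compound 2, a step that the two limits leave unreadable from compound 1 to compound 3 and a step that the two limits leave unreadable from compound 2 to compound 3 are all unreadable because of the limit of > 26000 nM in this assay, at which 3 of the 3 values shown sit.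

Compound 4 `CCOC(=O)CCCCCOc1cccc(CN(C(=O)c2ccc(-c3cccc(S(C)(=O)=O)c3)cc2)C(C)C)c1` has not yet been measured. It differs from compound 3 by methylsulfonyl in place of bromo on an aromatic carbon. The two measured steps that end at compound 3 are both unreadable, so no substituent change on this aromatic ring has so far moved any compound off the limit. The step expected in this assay is a step that the limit leaves unreadable from compound 3 to compound 4, with no movement beyond the scatter. Compound 4 is estimated at 40000 nM, within a range from 15000 nM to 200000 nM.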

Compound 4, half-maximal effective concentration: > 26000 nM
Compound 4 ended at the assay's limit; the forecaster's own chance of this, stated with the estimate: 85%; the middle value does not contradict the limit.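

In this assay compound 4 sits at a limit, as do compound 1, compound 2 and compound 3, and the steps joining compound 4 to those three cannot be read because of that shared limit: the limit of > 26000 nM in this assay, at which 4 of the 4 values shown sit.

The compounds shown leave open at what concentration any of the four reaches its half-maximal effect, and whether any substituent on this aromatic ring would move a compound off the limit.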